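This account rests on a few compounds, and the source may have more. Where it says the series, first, only, none or still open, it means among the compounds named here.

Compound 1, `O=C1C=C(Nc2ccc(Cl)cc2)C(=O)c2[nH]c(-c3ccccn3)nc21`, and compound 2, `O=C1C=C(Nc2ccc(Br)cc2)C(=O)c2[nH]c(-c3ccccn3)nc21`, share one core and differ in a single place: bromo in place of chloro on an aromatic carbon. In an ADME assay (Rattus norvegicus) for inhibition (a lower number here means a stronger inhibitor, a higher number a weaker inhibitor), compound 1 gives 13000 nM, while compound 2 gives 12000 nM; the step is a 1.1-fold lower number from compound 1 to compound 2 (0.03 log units; within the scatter). Compound 3, `Cc1nc2c(nc1C)C(=O)C(Nc1ccc(Cl)cc1)=CC2=O`, is built on a different core, and the difference between the two cores is not broken down here. In this assay compound 3 gives 3300 nM, the lowest of the three numbers, and its gap to both compound 1 and compound 2 lies beyond the scatter. Compound 4, `Cc1nc2c(nc1C)C(=O)C(Nc1ccc(Br)cc1)=CC2=O`, has not yet been measured. It stands to compound 3 as compound 2 stands to compound 1: bromo in place of chloro on an aromatic carbon, the same change at the same kind of place. Among these four compounds that change occurs twice in all. Because a 1.1-fold lower number from compound 1 to compound 2 (0.03 log units; within the scatter) stayed within the scatter, the expected step here is a 1.1-fold lower number from compound 3 to compound 4 (0.04 log units; within the scatter). Compound 4 is therefore expected to land at about 3000 nM in this assay, with a likely range from 1500 nM to 6500 nM.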

Compound 4, half-maximal inhibitory concentration: 1100 nM
Compound 4: middle estimate off by 2.7-fold (0.44 log units), on the high side; measured number below the stated range.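

In this assay, bromo in place of chloro on an aromatic carbon gives a 3.0-fold lower number from compound 3 to compound 4 (0.48 log units; beyond the scatter), a modest step but one that stands clear of the scatter. The size of this step therefore did not carry over from one core to the other, and the step seen on the core of compound 1 was a poor guide to the step on the core of compound 3: the same change on two cores in this assay, a 1.1-fold lower number (0.03 log units; within the scatter) from compound 1 to compound 2 and a 3.0-fold lower number (0.48 log units; beyond the scatter) from compound 3 to compound 4, 2.8-fold (0.44 log units) apart, beyond the scatter of two such steps. Going by these compounds alone, this shows that the effect of the swap depends on the core in these two pairs, but it does not show why, and with only two pairs it cannot say how the swap would behave on any further core.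

The compounds shown also leave open what other groups at the same place on the aromatic ring would do, such as fluoro, methyl, an amine or a carboxylic acid. They also leave open whether the difference between the two cores would persist with any of those groups in place of the chloro or bromo.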